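The source may report more compounds than this note shows. Statements on the series, on what has been measured and on what is new or still open speak of the compounds shown alone.

Measured so far:
compound 1 `CNC1CCN(c2ccc3[nH]nc(-c4cnn(C)c4)c3c2)C1`: "not determined" (no result reported)
compound 2 `Cn1cc(-c2n[nH]c3ccc(N[C@H]4CCNC4)cc23)cn1`: > 50000 nM
compound 3 `COc1ccc(-n2cc(-c3n[nH]c4cc(Cl)c(N[C@@H]5CCNC5)cc34)cn2)cc1`: 374 nM

In an assay on HEK293 cells for displacement of a labelled ligand from tyrosine-protein kinase receptor UFO (Homo sapiens), read by NanoBRET, with a stated time of 2 h (on this read-out lower numbers stand for stronger inhibition and higher numbers for weaker inhibition), compound 1 has no result. For compound 2 the entry is a limit of the assay and not a number, > 50000 nM; the limit is the one described as the limit of > 50000 nM in this assay, at which 1 of the 3 values shown sits. Among the measured compounds shown here, compound 3 is therefore the only compound of the three with a measured number in this assay, 374 nM, and it is the only point of reference for anything further.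

Compound 4 `Fc1ccc(-n2cc(-c3n[nH]c4cc(Cl)c(N[C@@H]5CCNC5)cc34)cn2)cc1` differs from compound 3 in one place: fluoro in place of methoxy on an aromatic carbon. The shared core, the chloro substituent and the pyrrolidinylamino group are kept; only the 4-methoxyphenyl on the pyrazole becomes 4-fluorophenyl. No measured pair in the set shows what such an exchange does, so there is no shown step to lean on. An exchange of this size is not expected to move this assay beyond the usual scatter in either direction; the step of a 1.1-fold higher number from compound 3 to compound 4 (0.05 log units; within the scatter) is the estimate. Compound 4 is expected to give about 420 nM, within 150 nM to 1200 nM.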

Compound 4, half-maximal inhibitory concentration: 684 nM
Compound 4: middle estimate off by 1.6-fold (0.21 log units), on the low side; the range from low to high includes it.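

Among the compounds shown here, the first measured step at this place comes from this assay: fluoro in place of methoxy on the aromatic carbon para to a large group gives a 1.8-fold higher number from compound 3 to compound 4 (0.26 log units; within the scatter). The 4-methoxyphenyl can therefore give way to the 4-fluorophenyl, with one heavy atom in place of two and no hydrogen-bond acceptor in the entering group, without a step beyond the scatter, and compound 4 still gives a measured number and not a limit. Nothing measured here gives a reason for this step.

Going by these compounds, what an amine, a carboxylic acid or a longer alkoxy chain at this place would do stays open. The entry for compound 2 is a limit of the assay and not a number, and that compound differs from compound 3 and compound 4 in more than one place, so no single change can be read from it.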